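A few compounds are considered here, and "the series" means these few. Any claim that something is new, unique, unknown or untested is made for them only; others in the source may bear on it.

Measured so far:
compound 1 `O=c1c2ccccc2c(-c2cccnc2)nn1Cc1ccccc1`: 97%
compound 2 `CCOC(=O)Cn1nc(-c2cccnc2)c2ccccc2c1=O`: 28%

In an assay on isolated protein (Oryctolagus cuniculus) with Thromboxane-A synthase (Homo sapiens) as the target, tested at 1 uM (on this read-out higher numbers stand for more inhibition at the one concentration tested (going by the name of the read-out) and lower numbers for less inhibition), compound 2 gives 28%, the lower of the two numbers; compound 1 gives 97%. For the measured compounds named here, the one step on record, a number 69 percentage points lower from compound 1 to compound 2 (beyond the scatter), is the only guide. Compound 3 `O=c1c2ccccc2c(-c2cccnc2)nn1CCSc1ncccn1` carries the change (((pyrimidin-2-yl)sulfanyl)methyl in place of ethoxycarbonyl on a saturated chain carbon bound to an aromatic nitrogen). It reintroduces an aromatic ring on the saturated chain carbon bound to the aromatic nitrogen, the feature whose removal went with the large drop from compound 1, so a large upward step is expected, a number 52 percentage points higher from compound 2 to compound 3 (beyond the scatter). Compound 3 is estimated at 80%, with a range of 45% to 97%.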

Compound 3, a percentage reported as inhibition, at one concentration (the size of the read-out at that concentration, not a potency): 86%
The estimate for compound 3 lay 6 percentage points below the measured number; measured number inside the range.
By their numbers in this assay, from the lowest: compound 2; then compound 3; then compound 1.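

In this assay, for the compounds shown here, phenyl is not the only group on a saturated chain carbon bound to an aromatic nitrogen that gives a high number. The change to ((pyrimidin-2-yl)sulfanyl)methyl gives a number 58 percentage points higher from compound 2 to compound 3 (beyond the scatter), yet a modest gap to phenyl remains, with a number 11 percentage points lower from compound 1 to compound 3 (beyond the scatter). Both groups carrying an aromatic ring stand above ethoxycarbonyl, with no compound here against that, but nothing measured explains the pattern.

Open, on these data alone, is whether the aromatic ring itself carries the gain, or whether a carboxylic acid or an amine on the same chain would give a similar number.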